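A few compounds are considered here, and "the series" means these few. Any claim that something is new, unique, unknown or untested is made for them only; others in the source may bear on it.

Measured in an ADME assay on microsomes from liver (Rattus norvegicus) for metabolic stability, with a stated time of 30 min; a lower number here means that less of the compound is left, a higher number that more of the compound is left:
- Compound 1 `Cc1cc(C(=O)c2cc(-c3ccc(Cl)cc3)n(-c3ccc(S(N)(=O)=O)cc3)c2C)ccc1Cl`: 38%
- Compound 2 `CC(=O)c1cc(-c2ccc(Cl)cc2)n(-c2ccc(S(N)(=O)=O)cc2)c1C`: 64%
- Compound 3 `Cc1c(C(=O)C2CC2)cc(-c2ccc(Cl)cc2)n1-c1ccc(S(N)(=O)=O)cc1`: 92%

Compound 3 stands highest of the three, with compound 2 nearest and compound 1 furthest. Compound 4 `Cc1c(C(=O)N2CCCC2)cc(-c2ccc(Cl)cc2)n1-c1ccc(S(N)(=O)=O)cc1` carries pyrrolidin-1-yl in place of cyclopropyl on a carbonyl carbon. For the measured compounds named here, three measured steps bear on this place: a number 26 percentage points higher from compound 1 to compound 2 (beyond the scatter), a number 28 percentage points higher from compound 2 to compound 3 (beyond the scatter) and a number 54 percentage points higher from compound 1 to compound 3 (beyond the scatter). None of them puts a hetero atom there, so they show how far this read-out can move, not which way it will go here. With compound 3 at 92% there is little room upward, so a modest fall is expected. The expected step is a number 22 percentage points lower from compound 3 to compound 4 (beyond the scatter). For compound 4 the estimated value is 70%, within an expected range of 45% to 90%.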

Compound 4, percent of the compound remaining: 31%
Compound 4: middle estimate off by 39 percentage points, on the high side, and the stated range ends above it.
By their numbers in this assay, from the lowest: compounds 4 and 1 (each within the scatter of the next); then compound 2; then compound 3.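

In this assay, for the compounds shown here, the first group to put a hetero atom on the carbonyl carbon gives a number 61 percentage points lower from compound 3 to compound 4 (beyond the scatter) and a number 33 percentage points lower from compound 2 to compound 4 (beyond the scatter). It also gives a number 7 percentage points lower from compound 1 to compound 4 (within the scatter), so pyrrolidin-1-yl does not retain the higher numbers seen with methyl or cyclopropyl. Nothing shown explains this fall.

The compounds shown leave open whether the fall follows from the nitrogen on the carbonyl carbon or from the larger ring. Cyclopentyl or an open-chain dimethylamino group at this place would separate those two readings.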